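Extending the Chain of Compound 2

This account rests on a few compounds, and the source may have more. Where it says the series, first, only, none or still open, it means among the compounds named here.

Two amides share one core. Compound 1 `CCCCCCCCNC(=O)[C@@H](NC(=O)c1ccco1)[C@@H](C)O` carries a furan-2-yl group on its carbonyl carbon, and in a functional assay on A-431 cells (Homo sapiens) for cytotoxicity, read by MTT assay, with a stated time of 48 h (a higher number here means a weaker inhibitor, a lower number a stronger inhibitor), compound 1 gives 64500 nM. Compound 2 `CCCCCCCCNC(=O)[C@@H](NC(=O)c1cccs1)[C@@H](C)O` carries thiophen-2-yl in its place, and in this assay compound 2 gives 32200 nM. The step of a 2.0-fold lower number from compound 1 to compound 2 (0.30 log units; within the scatter) lies within the scatter, so compound 2 stands with the lower of the two numbers but cannot be set apart from compound 1. Compound 3 `CCCCCCCCCCCCCCNC(=O)[C@@H](NC(=O)c1cccs1)[C@@H](C)O` is not yet measured; it differs from compound 2 by hexyl in place of hydrogen on a saturated chain carbon, eight bonds along the chain from an amide-type nitrogen. Among the compounds with values here, no measured step involves a change of this kind: the only step so far exchanges the ring on the carbonyl carbon and leaves the chain alone. The expectation therefore rests on compound 2 alone, with no direction to lean on and a wide range. Compound 3 is expected to give 25000 nM in this assay, between 6000 nM and 100000 nM, a step of a 1.3-fold lower number from compound 2 to compound 3 (0.11 log units; within the scatter) that is estimated to lie within the scatter.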

Compound 3, half-maximal inhibitory concentration: 26500 nM
The estimate for compound 3 lay 1.1-fold (0.03 log units) below the measured number; measured number inside the range.
By their numbers in this assay, from the lowest: compounds 3, 2 and 1 (each within the scatter of the next, the first and the last beyond it).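

In this assay, within the data shown here, the first change to the chain itself, hexyl in place of hydrogen on a saturated chain carbon, eight bonds along the chain from an amide-type nitrogen, gives a step (a 1.2-fold lower number from compound 2 to compound 3 (0.08 log units; within the scatter)) that lies within the scatter. Where the earlier compounds spoke only to an exchange of the ring on the carbonyl carbon, this pair shows that six added carbons at this position leave compound 2 and compound 3 impossible to set apart. No other data bear on this result, so it stands without explanation.

From the compounds shown here alone, whether a longer chain than that of compound 3, or an amine or a carboxylic acid in place of hexyl, would give a step beyond the scatter remains open. Also open, going by these compounds, is how furan-2-yl in place of thiophen-2-yl would read on the chain of compound 3.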